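Stereoisomers at the assay limit: compound 2 to compound 3

The source may report more compounds than this note shows. Statements on the series, on what has been measured and on what is new or still open speak of the compounds shown alone.

Compound 1 `Nc1nc2c(ncn2/C=C2/C[C@@H]2[C@@H](O)CO)c(=O)[nH]1`: > 300000 nM (limit)
Compound 2 `Nc1nc2c(ncn2/C=C2/C[C@H]2[C@H](O)CO)c(=O)[nH]1`: > 300000 nM (limit)

In an ADME assay on HFF cells (Homo sapiens) for cytotoxicity, read by neutral red uptake (on this read-out lower numbers stand for higher toxicity in this test and higher numbers for lower toxicity in this test), compound 2 gives > 300000 nM, which is a limit and not a number. Compound 1 gives > 300000 nM, which is likewise a limit. Compound 2 therefore has no exact position in the series, and the limit of > 300000 nM in this assay, at which 2 of the 2 values shown sit, applies to all of the data so far.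

Compound 3 `Nc1nc2c(ncn2/C=C2\C[C@H]2[C@@H](O)CO)c(=O)[nH]1` is related to compound 2 by the two compounds have the same atoms and bonds and differ only in configuration as drawn: 2 of 3 stereo elements differ; a stereocentre at a saturated chain carbon is drawn S in compound 2 and R in compound 3; a double bond is drawn Z in compound 2 and E in compound 3. No group leaves or enters, so the comparison concerns configuration alone.

Among the measured compounds shown here, one measured step bears on this change: a step that the two limits leave unreadable from compound 1 to compound 2. The relevant feature of that pair is the fact that compounds 1 and 2 differ only in the configuration as drawn. For the measured compounds named here, it is the only configuration-only comparison available, but it involves a different pair of stereo elements and gives no measurable size. It offers no basis for a shift in either direction, so no change beyond the scatter is expected in this assay.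

The estimated step is a number no higher from compound 2 to compound 3 (the limit leaves the size open). For compound 3 the expected value is 300000 nM, with an estimated range of 120000 nM to 600000 nM.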

Compound 3, half-maximal cytotoxic concentration: 298000 nM
Compound 3: middle estimate off by 1.0-fold (0.00 log units), on the high side; measured number inside the range.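

In this assay, among the compounds shown here, compound 3 gives 298000 nM, the first exact number. This gives a number no higher from compound 2 to compound 3 (the limit leaves the size open) and a number no higher from compound 1 to compound 3 (the limit leaves the size open). Neither step can be read, so changing the double bond from Z to E together with one stereocentre is not shown to raise or lower the read-out, and no size can be given for either change. The series now has one number for later comparisons, but the other values remain limits and not numbers: the limit of > 300000 nM in this assay, at which 2 of the 3 values shown sit.

Each pair shown changes two stereo elements at once, so the contribution of the double bond cannot be separated from that of the saturated ring carbon or the saturated chain carbon. Also open, as far as these compounds go, is how this assay would read with a change beyond configuration, such as an amine or a carboxylic acid in place of a hydroxyl group on the side chain.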